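Swapping the aryl ketone group on a chalcone-like scaffold

A few compounds are considered here, and "the series" means these few. Any claim that something is new, unique, unknown or untested is made for them only; others in the source may bear on it.

Two compounds share a core and differ only in the ring attached to the carbonyl carbon. Compound 1 `COc1cc(-c2cc(/C=C/C(=O)c3ccc(Cl)c(Cl)c3)[nH]n2)cc(OC)c1OC` carries a 3,4-dichlorophenyl there, and in a functional assay on HCC 2998 cells (Homo sapiens) for cytotoxicity, read by sulforhodamine B assay, with a stated time of 48 h, tested at 10 uM (on this read-out higher numbers stand for a weaker effect at the one concentration tested and lower numbers for a stronger effect), compound 1 gives 49%. Compound 2 `COc1ccc(C(=O)/C=C/c2cc(-c3cc(OC)c(OC)c(OC)c3)n[nH]2)cc1OC` carries a 3,4-dimethoxyphenyl instead, and in this assay compound 2 gives -85%, the lowest of the two numbers and so the stronger effect; the step of a number 134 percentage points lower from compound 1 to compound 2 (beyond the scatter) is well beyond the scatter. Compound 3 `COc1cc(-c2cc(/C=C/C(=O)c3ccc(F)c(F)c3)[nH]n2)cc(OC)c1OC` is not yet measured. Its change from compound 2 is 3,4-difluorophenyl in place of 3,4-dimethoxyphenyl on a carbonyl carbon. Among the measured compounds shown here, this undoes the only change studied so far, taking the 3,4-dimethoxyphenyl back out, so the one step that bears on it, a number 134 percentage points lower from compound 1 to compound 2 (beyond the scatter), suggests a move in the opposite direction, toward a weaker effect. As far as these compounds go, what a 3,4-difluorophenyl does in particular is untested. Compound 3 is therefore expected to show a number 110 percentage points higher from compound 2 to compound 3 (beyond the scatter) in this assay, giving an estimated 25%, within a range from -50% to 80%.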

Compound 3, a percentage reported as activity, at one concentration (the size of the read-out at that concentration, not a potency): 13%
Beside the measured number, compound 3's estimate is 12 percentage points above it; the range from low to high includes it.
By their numbers in this assay, from the lowest: compound 2; then compound 3; then compound 1.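

With a third ring on the carbonyl carbon, this position now shows a graded series rather than a single contrast: in this assay the 3,4-difluorophenyl ranks in the middle, with a number 98 percentage points higher from compound 2 to compound 3 (beyond the scatter) and also a number 36 percentage points lower from compound 1 to compound 3 (beyond the scatter). Both halogen-bearing rings give a weaker effect than the 3,4-dimethoxyphenyl, yet exchanging one halogen pair for the other still makes a large step, so the read-out here is not set simply by having a halogen pair on the ring. Nothing available explains why the three rings fall in this order.

Open, as far as these compounds go, is whether the methoxy groups are both needed, since a ring with a single methoxy group would separate their contributions. From the compounds shown here alone, how a dimethylamino group or a carboxylic acid on this ring would fare also remains open.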